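A Benzamido Replacement on Compound 3

A few compounds are considered here, and "the series" means these few. Any claim that something is new, unique, unknown or untested is made for them only; others in the source may bear on it.

Three compounds have so far been measured in an assay for inhibition of inositol hexakisphosphate kinase 3 (Homo sapiens), read by colorimetric assay, coupled enzyme assay and malachite green, with a stated time of 120 min, in the presence of a further agent that is not named here; a higher number here means a weaker inhibitor, a lower number a stronger inhibitor:
compound 1 `COC(=O)/C=C/c1ccc2noc(-c3ccccc3)c2c1`, where compound 1 gives 12100 nM
compound 2 `Cc1ccc(-c2onc3ccc(/C=C/C(=O)O)cc23)cc1`, where compound 2 gives 11500 nM
compound 3 `O=C(O)c1ccc2noc(-c3ccc(Oc4ccccn4)cc3)c2c1`, where compound 3 gives 2060 nM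

Compound 3 stands lowest of the three numbers in this assay. Its nearest neighbour is compound 2, whose number is higher by an amount beyond the usual scatter, and compound 1 lies further away still, also beyond the scatter. Compound 3 is therefore the strongest inhibitor among the measured compounds.

Compound 4 `O=C(O)c1ccc2noc(-c3ccc(NC(=O)c4ccccc4)cc3)c2c1` has not yet been measured in this assay. It differs from compound 3 in one place: benzamido in place of (pyridin-2-yl)oxy on an aromatic carbon. Among the compounds with values here, no pair of measured compounds shows this kind of exchange, so nothing among the measured numbers tells how large its effect should be. The expectation is a step within the usual scatter, with no clear direction, as given by a 1.2-fold higher number from compound 3 to compound 4 (0.08 log units; within the scatter). On that basis compound 4 is estimated to give 2500 nM in this assay, with a range from 700 nM to 9000 nM.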

Compound 4, half-maximal inhibitory concentration: 200 nM
Estimate against measurement, compound 4: 13-fold (1.10 log units) above, outside the stated range (below it).
By their numbers in this assay, from the lowest: compound 4; then compound 3; then compounds 2 and 1 (each within the scatter of the next).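

In this assay, benzamido in place of (pyridin-2-yl)oxy gives a 10-fold lower number from compound 3 to compound 4 (1.01 log units; beyond the scatter), showing that the number responds strongly to the group held on this aromatic carbon, para to a large group. The exchange replaces a six-membered aromatic ring with 1 hetero atom by one of carbon only, and 0 hydrogen-bond donors by 1 hydrogen-bond donor, but this single step cannot separate these differences. Nothing available bears on the reason for the step.

The compounds shown leave open whether the amide hydrogen matters, which benzamido carrying a methyl group on its nitrogen would address. They also leave open whether a plain phenoxy group would give a number nearer to that of compound 3 or compound 4.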